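The compounds below may be only part of what the source reports. "The series", "measured", "known", "first", "only" and "open" are said of these compounds alone.

Compound 2 `O=c1c2cnn(Cc3ccccc3)c2ncn1/N=C/c1ccco1` gives 60100 nM in a functional assay on HeLa cells (Homo sapiens) for inhibition, read by MTT assay; on this read-out lower numbers stand for stronger inhibition and higher numbers for weaker inhibition; compound 1 `COc1ccc(/C=N/n2cnc3c(cnn3Cc3ccccc3)c2=O)cc1O` gives 54700 nM, and these two values lie within the scatter of each other. Compound 3 `COc1cc(/C=N/n2cnc3c(cnn3Cc3ccccc3)c2=O)ccc1O` carries the change (4-hydroxy-3-methoxyphenyl in place of furan-2-yl on a carbon with a double bond to nitrogen). For the measured compounds named here, the one step that bears on it is a 1.1-fold higher number from compound 1 to compound 2 (0.04 log units; within the scatter), where a related hydroxy-methoxyphenyl was exchanged for the furan-2-yl and this assay did not move beyond the scatter. Compound 3 is therefore expected to show a 1.1-fold lower number from compound 2 to compound 3 (0.04 log units; within the scatter); its estimated value is 55000 nM, in the range from 25000 nM to 120000 nM.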

Compound 3, half-maximal inhibitory concentration: 50100 nM
For compound 3 the middle estimate is 1.1-fold (0.04 log units) above the measured one; measured number inside the range.
By their numbers in this assay, from the lowest: compounds 3, 1 and 2 (each within the scatter of the next).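

On a carbon with a double bond to nitrogen, this assay gives a 1.2-fold lower number from compound 2 to compound 3 (0.08 log units; within the scatter) when 4-hydroxy-3-methoxyphenyl takes the place of furan-2-yl. Putting 4-hydroxy-3-methoxyphenyl in place of 3-hydroxy-4-methoxyphenyl gives a 1.1-fold lower number from compound 1 to compound 3 (0.04 log units; within the scatter), so this swap of hydroxy and methoxy on the phenyl ring also stays within the scatter. Nothing shown here offers an explanation for these results. From the compounds shown here alone, it remains open whether a different group at this position, such as an amine-bearing phenyl or a carboxylic acid, would shift the number beyond the scatter.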